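Swapping a carbamoyl for a pyrazole-bearing ether on the core

The source may report more compounds than this note shows. Statements on the series, on what has been measured and on what is new or still open speak of the compounds shown alone.

Of the compounds shown here, two sharing one core have been measured in a functional assay on HEK293 cells for agonist activity at G-protein coupled receptor 39 (Homo sapiens), read by scintillation proximity assay and inositol phosphate accumulation, with a stated time of 75 min; a lower number here means that less compound is needed, a higher number that more compound is needed for the effect. Compound 1 `Cc1nn(-c2ncnc3nc[nH]c23)c2c1C(OCCn1cccn1)CC(=O)N2` gives 2270 nM in this assay, and compound 2 `Cc1nn(-c2ncnc3nc[nH]c23)c2c1C(C(=O)N(C)c1ccccc1)CC(=O)N2` gives 5220 nM. Compound 2 thus holds the higher of the two numbers, with compound 1 the nearer neighbour; the step of a 2.3-fold higher number from compound 1 to compound 2 (0.36 log units; beyond the scatter) is modest but beyond the scatter. Compound 3 `Cc1nn(-c2ncnc3nc[nH]c23)c2c1C(OCCn1nccc1C)CC(=O)N2` is not yet measured. It differs from compound 2 in that (a group of 9 heavy atoms (6 carbon, 2 nitrogen, 1 oxygen; one five-membered aromatic ring with 2 hetero atoms) in place of a group of 10 heavy atoms (8 carbon, 1 nitrogen, 1 oxygen; one six-membered aromatic ring of carbon only), on a saturated ring carbon). Within the data shown here, the only step that bears on this change is the one from compound 1 to compound 2, where 2-(1H-pyrazol-1-yl)ethoxy on a saturated ring carbon gave way to methyl(phenyl)carbamoyl; the entering group of compound 3 again carries a five-membered aromatic ring with 2 hetero atoms through an oxygen. A modest step downward is therefore expected, a 2.6-fold lower number from compound 2 to compound 3 (0.42 log units; beyond the scatter), placing compound 3 near compound 1. Compound 3 is estimated at 2000 nM, within 800 nM to 5000 nM.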

Compound 3, half-maximal effective concentration: 1620 nM
For compound 3 the middle estimate is 1.2-fold (0.09 log units) above the measured one; the measured number falls inside the stated range.
By their numbers in this assay, from the lowest: compounds 3 and 1 (each within the scatter of the next); then compound 2.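

In this assay a second ether carrying a five-membered aromatic ring with 2 hetero atoms, in place of methyl(phenyl)carbamoyl on the saturated ring carbon, gives a 3.2-fold lower number from compound 2 to compound 3 (0.51 log units; beyond the scatter), so the gap to the carbamoyl seen with the first ether recurs with this one. Methyl in place of hydrogen on an aromatic carbon of that ring gives only a 1.4-fold lower number from compound 1 to compound 3 (0.15 log units; within the scatter), so this change does not separate the two ethers in this assay. Nothing measured here accounts for either step.

Going by these compounds, how an amine, a carboxylic acid or a longer chain would read on the saturated ring carbon remains open. Also open, on these data alone, is whether an ethyl group in place of that methyl would move the number beyond the scatter.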